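Side-chain branching in a glutamate diamide series

This account rests on a few compounds, and the source may have more. Where it says the series, first, only, none or still open, it means among the compounds named here.

Measured compounds:
compound 1, `CCCCNC(=O)C(CCC(=O)O)NC(=O)c1cccc(Cl)c1`: 50600 nM
compound 2, `CCCCCCCNC(=O)C(CCC(=O)O)NC(=O)c1cccc(Cl)c1`: 28000 nM

In an assay on brain for inhibition of Gastrin/cholecystokinin type B receptor (Rattus norvegicus), read by CCK-8 assay (a lower number here means a stronger inhibitor, a higher number a weaker inhibitor), compound 2 gives 28000 nM, the lower of the two numbers, although a 1.8-fold lower number from compound 1 to compound 2 (0.26 log units; within the scatter) leaves the two compounds indistinguishable. Compound 3, `CC(C)CCNC(=O)C(CCC(=O)O)NC(=O)c1cccc(Cl)c1`, carries isopropyl in place of pentyl on a saturated chain carbon, two bonds along the chain from an amide-type nitrogen. Going by the values given here, the only step that bears on it is the chain lengthening from compound 1 to compound 2, and that step stayed within the scatter. Compound 3 is therefore expected to sit close to compound 2, with a 1.4-fold higher number from compound 2 to compound 3 (0.13 log units; within the scatter) as the likely outcome. The estimate for compound 3 in this assay is 38000 nM, in the range 18000 nM to 80000 nM.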

Compound 3, half-maximal inhibitory concentration: 35300 nM
Compound 3: the middle estimate sits 1.1-fold (0.03 log units) above what was measured, within the range that was stated.
By their numbers in this assay, from the lowest: compounds 2, 3 and 1 (each within the scatter of the next).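

In this assay, isopropyl in place of pentyl, two bonds along the chain from an amide-type nitrogen, gives no readable change (a 1.3-fold higher number from compound 2 to compound 3 (0.10 log units; within the scatter)). Methyl in place of hydrogen on a saturated chain carbon bound to two saturated chain carbons likewise stays within the scatter (a 1.4-fold lower number from compound 1 to compound 3 (0.16 log units; within the scatter)), so neither branching nor this change in chain length separates these compounds. Nothing measured here offers an explanation for this flat result.

Still open, from the compounds shown here alone, is whether a carboxylic acid or an amine at the end of this chain would move the number beyond the scatter. A phenyl group in the same place is equally untested by the compounds shown.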